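Replacing Iodine by Methyl on the Anilino Ring of Compound 1

This account rests on a few compounds, and the source may have more. Where it says the series, first, only, none or still open, it means among the compounds named here.

Compound 1 `O=c1oc(Nc2ccccc2I)nc2ccccc12`: 3500 nM
Compound 2 `CN(c1nc2ccccc2c(=O)o1)c1ccccc1I`: 1400 nM
Compound 3 `CCN(c1nc2ccccc2c(=O)o1)c1ccccc1I`: > 62500 nM

In an assay on isolated protein for inhibition of complement C1r subcomponent (Homo sapiens) (a lower number here means a stronger inhibitor, a higher number a weaker inhibitor), compound 1 gives 3500 nM, the higher of the two numbers measured; the nearest is compound 2 with 1400 nM, reached by a 2.5-fold lower number from compound 1 to compound 2 (0.40 log units; beyond the scatter). For compound 3 the assay gives only a limit, > 62500 nM, as noted in the limit of > 62500 nM in this assay, at which 1 of the 3 values shown sits.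

Compound 4 `Cc1ccccc1Nc1nc2ccccc2c(=O)o1` differs from compound 1 in one place: methyl in place of iodo on an aromatic carbon. Among the compounds with values here, none of the measured steps touches this position, since an at least 17-fold higher number from compound 1 to compound 3 (1.25 log units; beyond the scatter) and an at least 44-fold higher number from compound 2 to compound 3 (1.64 log units; beyond the scatter) concern only the nitrogen substituent. The expected size of the step is therefore uncertain, and compound 4 is estimated at 6000 nM (range 1500 nM to 25000 nM), meaning a 1.7-fold higher number from compound 1 to compound 4 (0.23 log units; within the scatter).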

Compound 4, half-maximal inhibitory concentration: 31000 nM
Compound 4: the middle estimate sits 5.2-fold (0.71 log units) below what was measured; measured number outside the range, above it.
By their numbers in this assay, from the lowest: compound 2; then compound 1; then compound 4. At a limit, above all of these: compound 3.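

In this assay, methyl in place of iodo gives an 8.9-fold higher number from compound 1 to compound 4 (0.95 log units; beyond the scatter), so the number responds to this aromatic carbon as well as to the nitrogen substituent. The step appears even though iodo and methyl match in their counts of heavy atoms, hydrogen-bond donors and hydrogen-bond acceptors. Nothing measured here accounts for its size.

On these data alone, whether chlorine, methoxy or an amine at this carbon would stay nearer compound 1 or compound 4 remains open. Also open, as far as these compounds go, is how a methyl on the nitrogen would act in compound 4.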